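A few compounds are considered here, and "the series" means these few. Any claim that something is new, unique, unknown or untested is made for them only; others in the source may bear on it.

Of the compounds shown here, two on one shared core have so far been read in a physicochemical assay for solubility, read by HPLC, using the shake flask method, measured as kinetic solubility, with a stated time of 20 h, at pH 6.5, tested at 200 uM; on this read-out lower numbers stand for lower solubility and higher numbers for higher solubility. Compound 1 (`O=S(=O)(c1cccc(-c2ccc3nccc(-c4ccncc4)c3n2)c1)N1CCC(O)CC1`) gives 10000 nM, and compound 2 (`CS(=O)(=O)Nc1cccc(-c2ccc3nccc(-c4ccncc4)c3n2)c1`) gives 20000 nM. For the measured compounds named here, compound 2 therefore stands within the scatter of compound 1, the only other compound measured, and the two cannot be ranked. Compound 3 (`CS(=O)(=O)c1cccc(-c2ccc3nccc(-c4ccncc4)c3n2)c1`) has not yet been measured. It differs from compound 2 in one place, an aromatic carbon of a six-membered aromatic ring of carbon only, meta to a large group, with methylsulfonyl in place of methanesulfonamido (methylsulfonyl in place of methanesulfonamido on an aromatic carbon). Going by the values given here, one measured step bears on this, and only indirectly: a 2.0-fold higher number from compound 1 to compound 2 (0.30 log units; within the scatter). That step also exchanges a group on an aromatic carbon, though not this pair of groups. On this single step, no shift beyond the scatter is expected in this assay, and the data favour no direction. The estimated step is a 1.3-fold lower number from compound 2 to compound 3 (0.12 log units; within the scatter). Compound 3 is expected at 15000 nM, with an estimated range from 5000 nM to 40000 nM.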

Compound 3, solubility: < 5000 nM
Compound 3 was reported as a limit; the forecaster's own chance of this, stated with the estimate: 5%; middle value at least 3.0-fold (0.47 log units) away from the limit.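

In this assay, the exchange of methanesulfonamido for methylsulfonyl on this aromatic carbon, meta to a large group, gives an at least 4.0-fold lower number from compound 2 to compound 3 (0.60 log units; beyond the scatter), so a change at this position can move the read-out beyond the scatter, which the earlier step, a 2.0-fold higher number from compound 1 to compound 2 (0.30 log units; within the scatter), did not show. The result for compound 3 is a limit of the assay and not a number: the limit of < 5000 nM in this assay, at which 1 of the 3 values shown sits. The comparison on the sulfonyl sulfur, methyl in place of 4-hydroxypiperidin-1-yl, gives an at least 2.0-fold lower number from compound 1 to compound 3 (0.30 log units; that floor lies within the scatter), and since that floor lies within the scatter, this step alone does not rank the two compounds.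

The compounds shown do not separate the parts of the change, since the group that leaves carries a nitrogen and a hydrogen-bond donor and the group that enters carries neither, and they do not fix the number behind the limit of compound 3. Going by these compounds, how an amine, a carboxylic acid or a longer chain on the sulfonyl sulfur would read on this aromatic carbon also remains open.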